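Losing the cyclopropylcarbonyl ester: a sulfone in its place

The compounds below may be only part of what the source reports. "The series", "measured", "known", "first", "only" and "open" are said of these compounds alone.

Values from a functional assay on A-375 cells (Homo sapiens) for cytotoxicity, read by MTT assay (on this read-out higher numbers stand for weaker inhibition and lower numbers for stronger inhibition), are as follows
compound 1 `COc1ccc(/C=C/C(=O)c2ccc(OC)c3c2OC(C)(C)C=C3)cc1OCC=C(C)C` gives > 10000 nM (a limit of the assay)
compound 2 `C#CCOc1cc(/C=C/C(=O)c2ccc(OC)c3c2OC(C)(C)C=C3)ccc1OC` gives > 10000 nM (a limit of the assay)
compound 3 `COc1ccc(/C=C/C(=O)c2ccc(OC)c3c2OC(C)(C)C=C3)cc1OC(=O)C1CC1` gives 380 nM (a measured number)

Among the compounds with values here, compound 3, at 380 nM, is the only compound here with an actual number. On these data alone, the other two rest on (the limit of > 10000 nM in this assay, at which 2 of the 3 values shown sit), so how far they lie from it is open.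

Compound 4 `COc1ccc(/C=C/C(=O)c2ccc(OC)c3c2OC(C)(C)C=C3)cc1CS(C)(=O)=O` carries (methylsulfonyl)methyl in place of (cyclopropylcarbonyl)oxy on an aromatic carbon, ortho to a methoxy group: (methylsulfonyl)methyl in place of (cyclopropylcarbonyl)oxy on an aromatic carbon.

Within the data shown here, two measured steps bear on this change, and both gained the group that compound 4 gives up. One is an at least 26-fold lower number from compound 1 to compound 3 (1.42 log units; beyond the scatter), and the other is an at least 26-fold lower number from compound 2 to compound 3 (1.42 log units; beyond the scatter). Both are large. Neither replaced the group with the one entering here, so they guide direction better than size. A clearly higher number, meaning weaker inhibition, is therefore expected in this assay, and a reading at the limit would be no surprise. The expected change is an 11-fold higher number from compound 3 to compound 4 (1.02 log units; beyond the scatter), a sizeable loss. For compound 4 the estimated value is 4000 nM, within a range of 700 nM to 10000 nM.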

Compound 4, half-maximal inhibitory concentration: > 10000 nM
Compound 4 ended at the assay's limit; the forecaster's own chance of this, stated with the estimate: 45%; middle value at least 2.5-fold (0.39 log units) from the limit.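

Placing (methylsulfonyl)methyl where compound 3 carries (cyclopropylcarbonyl)oxy gives, in this assay, an at least 26-fold higher number from compound 3 to compound 4 (1.42 log units; beyond the scatter). Within the data shown here, the incoming group is close in heavy-atom count and has the same count of hydrogen-bond acceptors as the one it replaces, so these two counts alone do not preserve the measured activity of compound 3, which remains the only compound here with a value short of the limit. The steps from compound 1 and from compound 2 to compound 4 cannot be read, and these three compounds cannot be ranked against one another: the limit of > 10000 nM in this assay, at which 3 of the 4 values shown sit.

On these data alone, it remains open whether the ester link or the cyclopropane ring matters more. An acetyl ester or a cyclopropyl amide at this position would help separate the two.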